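Ester chain on sulfur: from compound 3 to compound 4

The source may report more compounds than this note shows. Statements on the series, on what has been measured and on what is new or still open speak of the compounds shown alone.

Measured so far:
compound 1 `CCOC(=O)CCSc1nc2cc(-n3nc(C(C)(C)C)sc3=O)c(Cl)cc2s1` gives 1280 nM in an assay on isolated protein for inhibition of protoporphyrinogen oxidase (Homo sapiens), read by capillary electrophoresis; on this read-out higher numbers stand for weaker inhibition and lower numbers for stronger inhibition
compound 2 `CCOC(=O)CSc1nc2cc(-n3nc(C(C)(C)C)sc3=O)c(Br)cc2s1` gives 15600 nM
compound 3 `CCOC(=O)C(C)(C)Sc1nc2cc(-n3nc(C(C)(C)C)sc3=O)c(Br)cc2s1` gives 43500 nM

Compound 3 shows the highest number of the three, so the weakest inhibition seen in this set. Compound 4 `CCOC(=O)CCSc1nc2cc(-n3nc(C(C)(C)C)sc3=O)c(Br)cc2s1` differs from compound 3 in one place. The difference is 2-(ethoxycarbonyl)ethyl in place of 1-(ethoxycarbonyl)-1-methylethyl on a sulfur. Among the measured compounds shown here, one measured step bears on this sulfur group: a 2.8-fold higher number from compound 2 to compound 3 (0.45 log units; beyond the scatter), a modest rise. Compound 1 carries the very same 2-(ethoxycarbonyl)ethyl group on the sulfur and gives 1280 nM, a far lower number, although compound 1 also differs from compound 4 elsewhere, so that comparison is only a hint. A clear fall beyond the scatter is therefore expected, of roughly a 12-fold lower number from compound 3 to compound 4 (1.09 log units; beyond the scatter). Compound 4 is estimated at 3500 nM, likely between 900 nM and 14000 nM.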

Compound 4, inhibition constant: 27500 nM
Compound 4: the middle estimate sits 7.9-fold (0.90 log units) below what was measured, outside the stated range (above it).
By their numbers in this assay, from the lowest: compound 1; then compounds 2, 4 and 3 (each within the scatter of the next, the first and the last beyond it).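

With bromo on the core, the 2-(ethoxycarbonyl)ethyl group on the sulfur brings no clear shift in this assay: both a 1.6-fold lower number from compound 3 to compound 4 (0.20 log units; within the scatter) and a 1.8-fold higher number from compound 2 to compound 4 (0.25 log units; within the scatter) lie within the usual scatter. The large difference comes instead with the halogen, as a 21-fold higher number from compound 1 to compound 4 (1.33 log units; beyond the scatter) follows bromo in place of chloro on an aromatic carbon while the sulfur chain stays the same. Nothing shown explains this halogen difference. Still open, on these data alone, is whether chloro gives a similar gain with the other two ester chains, and how a carboxylic acid or a longer chain on the sulfur would compare.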